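The compounds below may be only part of what the source reports. "The series", "measured", "known", "first", "only" and "open" are said of these compounds alone.

Measured in an ADME assay on HEK293-A cells (Homo sapiens) for cytotoxicity, read by MTT assay, with a stated time of 48 h; a higher number here means a weaker inhibitor, a lower number a stronger inhibitor:

- compound 1, `CCN1CCN(C[C@H]2CN(c3ccc(-n4cc(-c5ccccn5)cn4)c(F)c3)C(=O)O2)CC1`: 99 ug/mL
- compound 2, `O=C(OC[C@H]1CN(c2ccc(-n3cc(-c4ccccn4)cn3)c(F)c2)C(=O)O1)c1ccccc1`: the value is a limit of the assay, > 400 ug/mL
- compound 3, `COC[C@H]1CN(c2ccc(-n3cc(-c4ccccn4)cn3)c(F)c2)C(=O)O1`: the value is a limit of the assay, > 400 ug/mL

Within the data shown here, compound 1 is the only member of the set with a definite number in this assay; the other two sit at the limit (the limit of > 400 ug/mL in this assay, at which 2 of the 3 values shown sit). Both changes made at the saturated chain carbon bound to a saturated ring carbon moved the number up: an at least 4.0-fold higher number from compound 1 to compound 2 (0.60 log units; beyond the scatter) and an at least 4.0-fold higher number from compound 1 to compound 3 (0.60 log units; beyond the scatter). The step between compound 2 and compound 3, a step that the two limits leave unreadable from compound 2 to compound 3, adds nothing about size.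

The next compound, compound 4, is `COC(=O)NC[C@H]1CN(c2ccc(-n3cc(-c4ccccn4)cn3)c(F)c2)C(=O)O1`. Its change from compound 1 is (methoxycarbonyl)amino in place of 4-ethylpiperazin-1-yl on a saturated chain carbon bound to a saturated ring carbon. It bears on the same place as the two measured steps, and in each of those the departure of the 4-ethylpiperazin-1-yl group was followed by an at least modest rise in the number. For compound 4 a rise of similar size in this assay is therefore expected, a 3.2-fold higher number from compound 1 to compound 4 (0.51 log units; beyond the scatter), with a good chance that only the limit is reported. The estimate for compound 4 in this assay is 320 ug/mL, within 130 ug/mL to 800 ug/mL.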

Compound 4, half-maximal inhibitory concentration: 306 ug/mL
Compound 4: the middle estimate sits 1.0-fold (0.02 log units) above what was measured; the range from low to high includes it.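

In this assay, compound 4 gives the series a second definite number, so the rise that follows the loss of the 4-ethylpiperazin-1-yl group on a saturated chain carbon bound to a saturated ring carbon now has a size and not only a floor (a 3.1-fold higher number from compound 1 to compound 4 (0.49 log units; beyond the scatter)). The entering (methoxycarbonyl)amino group has no ring and brings a hydrogen-bond donor, a third kind of replacement at this place, and it too leaves the number beyond the scatter from compound 1. Set against the two other replacements, compound 4 is not separated from either, as both floors lie within the scatter (an at least 1.3-fold lower number from compound 3 to compound 4 (0.11 log units; that floor lies within the scatter); an at least 1.3-fold lower number from compound 2 to compound 4 (0.11 log units; that floor lies within the scatter)).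

Going by these compounds, compound 2 and compound 3 remain limits of the assay, and the step between them cannot be read, so the order among the three replacements stays open: the limit of > 400 ug/mL in this assay, at which 2 of the 4 values shown sit. Also open, on these data alone, is whether the lower number of compound 1 goes with the piperazine ring itself or would persist with a morpholine ring or an open-chain amine such as diethylamino at this place.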